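This account rests on a few compounds, and the source may have more. Where it says the series, first, only, none or still open, it means among the compounds named here.

In a functional assay (brain) for inhibition, with Rattus norvegicus as the target (on this read-out lower numbers stand for stronger inhibition and higher numbers for weaker inhibition), compound 2 `Cc1c(C)c2c(c(C)c1O)CCC(C)(CC[N+](C)(C)C)O2` gives 2600 nM, the lowest of the three numbers recorded, though compound 3 `CSCCC1(C)CCc2c(C)c(O)c(C)c(C)c2O1` with 3000 nM lies within the usual scatter of it, as a 1.2-fold higher number from compound 2 to compound 3 (0.06 log units; within the scatter) shows. Compound 1 `Cc1c(C)c2c(c(C)c1O)CCC(C)(C(=O)[N-][N+](C)(C)C)O2` gives 14000 nM, and both a 5.4-fold lower number from compound 1 to compound 2 (0.73 log units; beyond the scatter) and a 4.7-fold lower number from compound 1 to compound 3 (0.67 log units; beyond the scatter) are beyond the scatter. Compound 4 `Cc1c(C)c2c(c(C)c1O)CC[C@](C)(CC[N+](C)(C)C)O2` differs from compound 2 only in the two compounds have the same atoms and bonds; at least one stereo element is drawn with a configuration in one of them and without one in the other: 1 of 1 stereo elements differ; a stereocentre at a saturated ring carbon is drawn without a configuration in compound 2 and R in compound 4. For the measured compounds named here, none of the measured steps concerns a stereocentre; each exchanges one group for another, so no measured step bears on this change. Fixing one configuration where none was drawn is expected to shift the number at most modestly, toward a lower value if at all. Compound 4 is therefore estimated at 2000 nM, within 800 nM to 5000 nM, a step of a 1.3-fold lower number from compound 2 to compound 4 (0.11 log units; within the scatter) expected to stay within the scatter.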

Compound 4, half-maximal inhibitory concentration: 2200 nM
Compound 4: middle estimate off by 1.1-fold (0.04 log units), on the low side, and the stated range covers the measured number.
By their numbers in this assay, from the lowest: compounds 4, 2 and 3 (each within the scatter of the next); then compound 1.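

In this assay, for the compounds shown here, the first change at the saturated ring carbon that leaves its groups untouched gives a 1.2-fold lower number from compound 2 to compound 4 (0.07 log units; within the scatter), so drawing the R configuration there leaves no difference that can be read. The earlier steps shown here exchanged groups at this carbon or along its chain, whereas this comparison isolates the stereocentre and rests on one difference: the fact that one of compounds 2 and 4 is drawn with a defined configuration and the other without, at the place where they differ. On these data alone, what the S configuration at this carbon would give stays open, as does whether a primary amine or a carboxylic acid on the chain of compound 4 would keep the number in this range.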